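Swapping an allyl ether for an azide: a cytotoxicity outlook

A few compounds are considered here, and "the series" means these few. Any claim that something is new, unique, unknown or untested is made for them only; others in the source may bear on it.

Measured so far in an ADME assay on Huh-5-2 cells (Homo sapiens) for cytotoxicity, with a stated time of 3 days; on this read-out lower numbers stand for higher toxicity in this test and higher numbers for lower toxicity in this test:
- compound 1 `COC[C@H]1C[C@@](CC(C)C)(C(=O)O)N(C(=O)c2ccc(C(C)(C)C)c(OC)c2)[C@H]1C(N)=O` gives > 120000 nM, which is a limit of the assay.
- compound 2 `COC[C@H]1C[C@@](CC(C)C)(C(=O)O)N(C(=O)c2ccc(C(C)(C)C)c(OC)c2)[C@H]1C(=O)OC` gives > 120000 nM, which is a limit of the assay.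
- compound 3 `C=CCOC[C@H]1[C@@H](COC)C[C@@](CC(C)C)(C(=O)O)N1C(=O)c1ccc(C(C)(C)C)c(OC)c1` gives > 120000 nM, which is a limit of the assay.

Compound 3 therefore stands only at a limit, as do the two other measured compounds, all sitting at the limit of > 120000 nM in this assay, at which 3 of the 3 values shown sit. Going by the values given here, none of the measured steps can be read: a step that the two limits leave unreadable from compound 1 to compound 2, a step that the two limits leave unreadable from compound 1 to compound 3 and a step that the two limits leave unreadable from compound 2 to compound 3 all run between two limits, so their sizes are not known.

Compound 4 `COC[C@H]1C[C@@](CC(C)C)(C(=O)O)N(C(=O)c2ccc(C(C)(C)C)c(OC)c2)[C@H]1CN=[N+]=[N-]` is not yet measured. It differs from compound 3 as follows: azido in place of allyloxy on a saturated chain carbon bound to a saturated ring carbon. Among the compounds with values here, the measured steps bear on this only in that every change tried so far, whether at the carbonyl carbon or at the saturated ring carbon, has left the read-out at the limit; no step gives a direction or a size. The expectation for this assay is accordingly a step that the limit leaves unreadable from compound 3 to compound 4, that is, nothing beyond the scatter, with a good chance of another limit. Compound 4 is estimated at 150000 nM, between 60000 nM and 400000 nM.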

Compound 4, half-maximal cytotoxic concentration: > 120000 nM
Compound 4: only a limit was reported (the forecaster's own chance of this, stated with the estimate: 85%); the middle value does not contradict the limit.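

In this assay compound 4 gives > 120000 nM, which is a limit of the assay. The steps to compound 4 from compound 1, compound 2 and compound 3 therefore cannot be read: the limit of > 120000 nM in this assay, at which 4 of the 4 values shown sit.

The compounds shown leave open whether any of these changes affects cytotoxicity at all.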